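The source may report more compounds than this note shows. Statements on the series, on what has been measured and on what is new or still open speak of the compounds shown alone.

Measured so far in an ADME assay on MDBK cells (Bos taurus) for cytotoxicity, read by MTT assay, with a stated time of 96 h; a lower number here means that less compound is tolerated, a higher number that more compound is tolerated:
compound 1 `CCCC[C@H]1CC[C@H](c2ccc(NC(=S)Nc3cccc(C(F)(F)F)c3)cc2)CC1`: 10000 nM
compound 2 `CCNC(=S)Nc1cccc(C(F)(F)F)c1`: > 100000 nM

Of these two entries, only compound 1 has an actual number, 10000 nM. The entry for compound 2, > 100000 nM, is a limit of the assay and not a number. Going by the values given here, compound 1 therefore stands lower in this assay than the limit reached by compound 2, and no step between compounds differing in one place is available.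

Next is compound 3 `CCOC(=O)c1ccc(NC(=S)Nc2cccc(C(F)(F)F)c2)cc1`, which carries ethoxycarbonyl in place of 4-butylcyclohexyl on an aromatic carbon, para to a large group (ethoxycarbonyl in place of 4-butylcyclohexyl on an aromatic carbon). Among the compounds with values here, no measured step covers this change, so the expectation is only a rough one. A moderate move beyond the scatter towards more compound being tolerated is expected in this assay. This leans on compound 2, whose > 100000 nM is a limit. The estimated step runs a 3.0-fold higher number from compound 1 to compound 3 (0.48 log units; beyond the scatter). For compound 3 the expected value is 30000 nM, with an estimated range of 10000 nM to 100000 nM.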

Compound 3, half-maximal cytotoxic concentration: 64000 nM
Compound 3: the middle estimate sits 2.1-fold (0.33 log units) below what was measured; low and high end bracket the measured number.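

Ethoxycarbonyl in place of 4-butylcyclohexyl, on an aromatic carbon para to a large group, gives in this assay a 6.4-fold higher number from compound 1 to compound 3 (0.81 log units; beyond the scatter), so the number in this assay does move with the group at this position. The change is not a single variable: a non-aromatic ring of carbon and its defined stereocentres leave, while oxygen, a double bond outside aromatic rings and hydrogen-bond acceptors enter, and the data cannot divide the step among these features. The entry for compound 2 remains a limit and not a number, so it gives no measured step in this series: the limit of > 100000 nM in this assay, at which 1 of the 3 values shown sits.

Which part of the change carries the step remains open, and so does whether the ethoxycarbonyl group itself matters or only the loss of 4-butylcyclohexyl. A plain butyl chain in place of 4-butylcyclohexyl, or a carboxylic acid or a primary amide in place of ethoxycarbonyl, would begin to separate the ring, the chain and the ester at this position.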